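Chloro in place of vinyl: compound 3 to compound 4

The source may report more compounds than this note shows. Statements on the series, on what has been measured and on what is new or still open speak of the compounds shown alone.

In an ADME assay on HEK293 cells (Homo sapiens) for cytotoxicity, read by resazurin assay, with a stated time of 48 h (a lower number here means that less compound is tolerated, a higher number that more compound is tolerated), compound 1 `O=S(=O)(Nc1ccc(-c2nc3ccccc3o2)cc1)c1cccc(F)c1` gives > 100000 nM, which is a limit of the assay and not a number. Compound 2 `O=S(=O)(Nc1ccc(-c2nc3ccccc3o2)cc1)c1ccc(Cl)s1` gives > 100000 nM, again a limit and not a number. For the measured compounds named here, compound 3 `C=Cc1ccc(S(=O)(=O)Nc2ccc3oc(-c4ccccc4)nc3c2)cc1` gives 53000 nM, the only true number in the set. The series is therefore marked by the limit of > 100000 nM in this assay, at which 2 of the 3 values shown sit.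

Compound 4 `O=S(=O)(Nc1ccc2oc(-c3ccccc3)nc2c1)c1ccc(Cl)cc1` has chloro in place of vinyl on an aromatic carbon, para to a large group (chloro in place of vinyl on an aromatic carbon).

Going by the values given here, the only measured step is a step that the two limits leave unreadable from compound 1 to compound 2, with 5-chlorothiophen-2-yl in place of 3-fluorophenyl on a sulfonyl sulfur. Among the compounds with values here, it lies at another place on the molecule and gives no usable size, so no measured step bears on this change. The expectation in this assay therefore stays anchored on compound 3 at 53000 nM, with no shift beyond the scatter in either direction. The expected move is a 1.2-fold higher number from compound 3 to compound 4 (0.09 log units; within the scatter). For compound 4 the estimate is 65000 nM, with an expected range of 30000 nM to 100000 nM.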

Compound 4, half-maximal cytotoxic concentration: 65000 nM
The estimate for compound 4 equals the measured number at the digits printed, within the range that was stated.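

Chloro in place of vinyl, on an aromatic carbon para to a large group, gives a 1.2-fold higher number from compound 3 to compound 4 (0.09 log units; within the scatter) in this assay. For the compounds shown here, this is the first step in the set that can be read, as the step between compound 1 and compound 2 cannot, and it shows that vinyl and chloro at this position cannot be told apart in this assay. Only compound 3 and compound 4 carry true numbers, and the rest of the set is marked by a limit: the limit of > 100000 nM in this assay, at which 2 of the 4 values shown sit.

The compounds shown leave open whether an amine or a carboxylic acid at this position would also stay within the scatter of compound 3. They also leave compound 1 and compound 2 without a readable comparison to compound 4, as each differs from it in more than one place.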